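The source may hold more compounds than are shown below. What is called first, only, known or untested is meant among the compounds shown, and "the series" means these compounds.

Two dichloroacetamides of anilines have been measured in a functional assay on A549 cells (Homo sapiens) for antiproliferative activity, read by MTT assay, with a stated time of 72 h; a lower number here means a stronger inhibitor, a higher number a weaker inhibitor. Compound 1 `O=C(Nc1cccc(Cl)c1)C(Cl)Cl` carries a chloro group on its ring, and in this assay compound 1 gives 14800 nM. Compound 2 `O=C(Nc1cccc(Br)c1)C(Cl)Cl` is the same molecule with bromo in place of that chloro, and in this assay compound 2 gives 7800 nM. Going by the values given here, of the two numbers so far, the one for compound 2 is the lower, yet the only step between them, a 1.9-fold lower number from compound 1 to compound 2 (0.28 log units; within the scatter), is within the scatter, so the two compounds cannot be told apart.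

Compound 3 `O=C(Nc1cccc([N+](=O)[O-])c1)C(Cl)Cl` is the next variation: nitro in place of bromo on an aromatic carbon. Among the compounds with values here, only one measured step exists, the halogen swap from compound 1 to compound 2, and it was a 1.9-fold lower number from compound 1 to compound 2 (0.28 log units; within the scatter). Within the data shown here, no measured step involves a nitro group, so the exchange has no direct precedent; the one step available was within the scatter. The expectation is therefore a step of about a 1.2-fold higher number from compound 2 to compound 3 (0.06 log units; within the scatter), which lies within the scatter. Compound 3 is thus expected to give roughly 9000 nM, with a plausible range from 3000 nM to 27000 nM.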

Compound 3, half-maximal inhibitory concentration: 18000 nM
The estimate for compound 3 lay 2.0-fold (0.30 log units) below the measured number; the range from low to high includes it.
By their numbers in this assay, from the lowest: compounds 2, 1 and 3 (each within the scatter of the next, the first and the last beyond it).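

Going by these compounds alone, at this place on the ring, the exchange of bromo for nitro gives the first step beyond the scatter in this assay (a 2.3-fold higher number from compound 2 to compound 3 (0.36 log units; beyond the scatter)), so the group held here can shift the number, though only modestly; the halogen swap could not show this. The same nitro group cannot be told apart from chloro (a 1.2-fold higher number from compound 1 to compound 3 (0.09 log units; within the scatter)), which means that the larger substituent, with its three heavy atoms and two hydrogen-bond acceptors, is separated only from bromo, and that one step is the entire signal so far. No measurement available here accounts for the step from bromo to nitro.

The compounds shown leave open how this position would respond to quite different groups, such as an amine, a carboxylic acid or a methoxy group, and so whether any group here could move the number well beyond this modest range. They also leave open whether nitro or bromo would give a step of similar size at another place on the ring.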